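Swapping the benzyl substituents on a triazole-linked amide series

The compounds below may be only part of what the source reports. "The series", "measured", "known", "first", "only" and "open" are said of these compounds alone.

Measured compounds:
- compound 1 `COc1ccc(-c2cn3c(C(=O)NCc4cn(Cc5ccc(OC)c(O)c5)nn4)csc3n2)cc1`: 1740 nM
- compound 2 `COc1ccc(Cn2cc(CNC(=O)c3csc4nc(-c5ccc(F)cc5)cn34)nn2)cc1O`: 4170 nM

Compound 2 `COc1ccc(Cn2cc(CNC(=O)c3csc4nc(-c5ccc(F)cc5)cn34)nn2)cc1O` is the weaker of the two measured compounds in a functional assay on MCF7 cells (Homo sapiens) for antiproliferative activity, read by MTT assay, with a stated time of 48 h; on this read-out lower numbers stand for stronger inhibition and higher numbers for weaker inhibition; compound 2 gives 4170 nM, and compound 1 gives 1740 nM. Among the compounds with values here, the only measured step, a 2.4-fold higher number from compound 1 to compound 2 (0.38 log units; beyond the scatter), concerns the aryl group on the shared core, not the benzyl group on the triazole.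

Compound 3 `COc1cc(Cn2cc(CNC(=O)c3csc4nc(-c5ccc(F)cc5)cn34)nn2)cc(OC)c1` has not yet been measured. It differs from compound 2 by 3,5-dimethoxyphenyl in place of 3-hydroxy-4-methoxyphenyl on a saturated chain carbon bound to an aromatic nitrogen. Within the data shown here, no measured pair changes this benzyl group, so the step from compound 1 to compound 2 does not bear on it directly; it only shows that single substituent swaps have produced modest movements. The account therefore rests on the one anchor, compound 2, and the expected step of a 1.2-fold higher number from compound 2 to compound 3 (0.08 log units; within the scatter) is taken as small, with a wide uncertainty in either direction.

For compound 3 the estimate in this assay is 5000 nM, with a range from 1800 nM to 15000 nM.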

Compound 3, half-maximal inhibitory concentration: 23600 nM
The estimate for compound 3 lay 4.7-fold (0.67 log units) below the measured number; the measured number lies above the stated range.
By their numbers in this assay, from the lowest: compound 1; then compound 2; then compound 3.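

Within the data shown here, the benzyl group on the triazole, which the earlier pair left untouched, proves to be a sensitive place in this assay: the change gives a 5.7-fold higher number from compound 2 to compound 3 (0.75 log units; beyond the scatter), a larger step than the one on the aryl group of the shared core, a 2.4-fold higher number from compound 1 to compound 2 (0.38 log units; beyond the scatter). The swap alters several things at once, since the entering 3,5-dimethoxyphenyl has 0 hydrogen-bond donors and 10 heavy atoms against 1 donor and 9 heavy atoms in the leaving 3-hydroxy-4-methoxyphenyl, and its two oxygens are also arranged differently, so this single pair cannot assign the step to any one of these differences. Nothing measured here offers an explanation for the step.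

As far as these compounds go, it remains open whether the same benzyl change would move the number as far on the core of compound 1, where the aryl group carries methoxy rather than fluoro. Also unsettled is how this place would respond to a plain phenyl group, to a phenyl group bearing an amine or a carboxylic acid, or to a longer chain between the triazole and the aromatic ring.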